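This account rests on a few compounds, and the source may have more. Where it says the series, first, only, none or still open, it means among the compounds named here.

In a functional assay on HCT-116 cells (Homo sapiens) for inhibition, read by MTT assay, with a stated time of 48 h (a higher number here means a weaker inhibitor, a lower number a stronger inhibitor), compound 1 (`COc1ccc(-n2c(SCc3ccc(C)cc3)nnc2-c2cc(OC)c(OC)c(OC)c2)cc1`) gives 33300 nM. Compound 2 (`COc1cc(-c2nnc(S)n2-c2ccc(N(C)C)cc2)cc(OC)c1OC`) returns only a limit, > 60000 nM. Compound 3 (`COc1cc(-c2nnc(SCc3ccc(C)cc3)n2-c2ccc(N(C)C)cc2)cc(OC)c1OC`) also returns only a limit, > 60000 nM, so it has no number of its own and stands at the limit of > 60000 nM in this assay, at which 2 of the 3 values shown sit.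

Compound 4 (`COc1cc(-c2nnc(SCC(=O)c3ccc4ccccc4c3)n2-c2ccc(N(C)C)cc2)cc(OC)c1OC`) carries (naphthalen-2-yl)carbonyl in place of 4-methylphenyl on a saturated chain carbon bound to a sulfur.

Two measured steps lead into compound 3. The first, an at least 1.8-fold higher number from compound 1 to compound 3 (0.25 log units; that floor lies within the scatter), concerns dimethylamino in place of methoxy on an aromatic carbon, a group that compound 4 retains. Among the measured compounds shown here, the second, a step that the two limits leave unreadable from compound 2 to compound 3, is the only one that changes the substituent on sulfur, and it gives no usable size. Neither step therefore sizes the new change, and no direction can be read for this assay. Compound 4 shares dimethylamino with compound 2 and compound 3, both of which sit at the limit, so it is expected to remain weak.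

The expected step is an at least 1.3-fold lower number from compound 3 to compound 4 (0.12 log units; that floor lies within the scatter), with a limit result quite possible. The estimate for compound 4 is 45000 nM, with an expected range of 10000 nM to 80000 nM.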

Compound 4, half-maximal inhibitory concentration: 54500 nM
Estimate against measurement, compound 4: 1.2-fold (0.08 log units) below; low and high end bracket the measured number.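

In this assay, compound 4 is the only compound shown with dimethylamino that has a number of its own, so a (naphthalen-2-yl)carbonyl group on a saturated chain carbon bound to a sulfur is compatible with a measurable result in this part of the series. The exchange for 4-methylphenyl gives an at least 1.1-fold lower number from compound 3 to compound 4 (0.04 log units; that floor lies within the scatter), so this floor shows no change beyond the scatter, even with 12 heavy atoms entering for 7 and a hydrogen-bond acceptor added. Compound 2 and compound 3 remain limits rather than numbers: the limit of > 60000 nM in this assay, at which 2 of the 4 values shown sit.

Going by these compounds, the true size of the step to compound 4 stays open, and the step from compound 2 to compound 3 cannot be read. Also open, on these data alone, is how a primary amine or a carboxylic acid would read at this chain carbon bound to a sulfur.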